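The source may hold more compounds than are shown below. What is called first, only, known or untested is meant among the compounds shown, and "the series" means these compounds.

Measured in an ADME assay on the whole organism (Rattus norvegicus, strain Sprague-Dawley) for metabolic stability, read by LC-MS, with a stated time of 72 h, at a dose of 1 mg/kg by the intravenous route; a lower number here means that the compound disappears faster, a higher number that the compound lasts longer:
- compound 1 `CN1CC[C@@H](N(c2cc(C#CC(C)(C)C)sc2C(=O)O)C(=O)[C@H]2CC[C@H](C)CC2)C1=O`: 2.73 h
- compound 2 `CN1CC[C@H](N(c2cc(C#CC(C)(C)C)sc2C(=O)O)C(=O)[C@H]2CC[C@H](C)CC2)C1=O`: 3.07 h

For the measured compounds named here, compound 2 stands within the scatter of compound 1, the only other compound measured. Compound 3 `CN1CCCC[C@@H](N(c2cc(C#CC(C)(C)C)sc2C(=O)O)C(=O)[C@H]2CC[C@H](C)CC2)C1=O` has 1-methyl-2-oxoazepan-3-yl in place of the 1-methyl-2-oxopyrrolidin-3-yl of compound 2 on an amide-type nitrogen (1-methyl-2-oxoazepan-3-yl in place of 1-methyl-2-oxopyrrolidin-3-yl on an amide-type nitrogen). Going by the values given here, only one measured step can serve as a guide, and it is a 1.1-fold higher number from compound 1 to compound 2 (0.05 log units; within the scatter). That step is small, but it reflects (the fact that compounds 1 and 2 differ only in the configuration as drawn), and the ring itself stays the same in it. The data therefore give no direct measure of what a change of ring size does in this assay, and no step beyond the scatter is expected in either direction. The estimate means a 1.0-fold lower number from compound 2 to compound 3 (0.01 log units; within the scatter), an expected step that stays within the scatter. Compound 3 is expected at 3 h, with an estimated range from 1.5 h to 6 h.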

Compound 3, half-life: 2.79 h
For compound 3 the middle estimate is 1.1-fold (0.03 log units) above the measured one; measured number inside the range.
By their numbers in this assay, from the lowest: compounds 1, 3 and 2 (each within the scatter of the next).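

In this assay, for the compounds shown here, this is the first reading of a change of ring size on the amide-type nitrogen, as the earlier step kept the ring the same: the fact that compounds 1 and 2 differ only in the configuration as drawn. Placing 1-methyl-2-oxoazepan-3-yl where 1-methyl-2-oxopyrrolidin-3-yl stood gives a 1.1-fold lower number from compound 2 to compound 3 (0.04 log units; within the scatter), and read against the other drawn form it gives a 1.0-fold higher number from compound 1 to compound 3 (0.01 log units; within the scatter). Both steps lie within the scatter, so among these three compounds the seven-membered ring cannot be told apart from the five-membered ring by half-life.

From the compounds shown here alone, it remains open whether a six-membered ring on the same nitrogen, or a group of another kind such as a dimethylamino chain or a carboxylic acid, would hold the number at this level. Going by these compounds, what the opposite configuration does on the seven-membered ring also remains open.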